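The compounds below may be only part of what the source reports. "The series", "measured", "known", "first", "only" and "open" are said of these compounds alone.

Measured so far:
- compound 1 `CC(C)(C)OC(=O)N1CCC(Oc2cccc3c2CCN3c2ccc(S(C)(=O)=O)cc2)CC1`: 92%
- compound 2 `COC(=O)N1CCC(Oc2ncnc3c2CCN3c2ccc(S(C)(=O)=O)cc2F)CC1`: 119%

In a functional assay on CHO-K1 cells with Glucose-dependent insulinotropic receptor (Homo sapiens) as the target, read by a luciferase reporter, with a stated time of 5 h (a lower number here means a smaller maximal response, a higher number a larger maximal response), compound 2 gives 119%, the higher of the two numbers, while compound 1 gives 92%, a gap beyond the usual scatter. Compound 3 `CCS(=O)(=O)N1CCC(Oc2ncnc3c2CCN3c2ccc(S(C)(=O)=O)cc2F)CC1` differs from compound 2 in a single place: ethylsulfonyl in place of methoxycarbonyl on an amine nitrogen in a ring. Going by the values given here, no measured pair shows this change, so its effect on the maximal response is unknown. The expected step is a number 7 percentage points lower from compound 2 to compound 3 (within the scatter), a shift that stays within the usual scatter. The estimated value for compound 3 is 112%, with a likely range from 88% to 136%.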

Compound 3, largest response reached (reported as percent of maximum), in percent of the reference or control that the assay uses: 51%
Compound 3: the middle estimate sits 61 percentage points above what was measured, and the stated range ends above it.
By their numbers in this assay, from the lowest: compound 3; then compound 1; then compound 2.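

The group on the amine nitrogen in the six-membered non-aromatic ring matters greatly in this assay: ethylsulfonyl in place of methoxycarbonyl gives a number 68 percentage points lower from compound 2 to compound 3 (beyond the scatter). Neither group has a ring, a net charge or a hydrogen-bond donor, so those shared counts do not predict the outcome. No measurement shown gives a reason for this drop. As far as these compounds go, it remains open whether the sulfonyl link or the ethyl chain goes with the lower response. An acetyl group or a propylsulfonyl group on that nitrogen could help separate these two possibilities.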